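A fourth variation at the carbon double-bonded to nitrogen

The source may hold more compounds than are shown below. What is called first, only, known or untested is meant among the compounds shown, and "the series" means these compounds.

Three compounds share one core and differ only in the group on a carbon with a double bond to nitrogen. In a functional assay on A549 cells (Homo sapiens) for cytotoxicity, read by MTT assay, with a stated time of 72 h (on this read-out higher numbers stand for weaker inhibition and lower numbers for stronger inhibition), compound 1 `CN(C)CCn1cnnc1-c1cc(Oc2ccc(NC(=O)N/N=C/c3cccc(Br)c3)cc2F)ccn1` gives 970 nM, compound 2 `CN(C)CCn1cnnc1-c1cc(Oc2ccc(NC(=O)N/N=C/c3ccc(F)cc3Cl)cc2F)ccn1` gives 1120 nM, and compound 3 `CN(C)CCn1cnnc1-c1cc(Oc2ccc(NC(=O)N/N=C/c3c(O)ccc4ccccc34)cc2F)ccn1` gives 880 nM. The gaps between them are small: a 1.2-fold higher number from compound 1 to compound 2 (0.06 log units; within the scatter), a 1.1-fold lower number from compound 1 to compound 3 (0.04 log units; within the scatter) and a 1.3-fold lower number from compound 2 to compound 3 (0.10 log units; within the scatter). Compound 4 `Cc1cc(/C=N/NC(=O)Nc2ccc(Oc3ccnc(-c4nncn4CCN(C)C)c3)c(F)c2)cc(C)c1O` changes the same position: 4-hydroxy-3,5-dimethylphenyl in place of 2-hydroxynaphthalen-1-yl on a carbon with a double bond to nitrogen. Among the compounds with values here, the steps that bear on this are exactly these three swaps at the same carbon, and none of them moved this assay beyond the scatter, so no step beyond the scatter is expected here either. Compound 4 is therefore expected to give 950 nM, with a range from 450 nM to 2000 nM. This estimate means a 1.1-fold higher number from compound 3 to compound 4 (0.03 log units; within the scatter).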

Compound 4, half-maximal inhibitory concentration: 1640 nM
The estimate for compound 4 lay 1.7-fold (0.24 log units) below the measured number; the range from low to high includes it.
By their numbers in this assay, from the lowest: compounds 3, 1, 2 and 4 (each within the scatter of the next).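

In this assay, the position also accepts 4-hydroxy-3,5-dimethylphenyl, with one six-membered aromatic ring where 2-hydroxynaphthalen-1-yl has two, and all three new steps stay within the scatter (a 1.9-fold higher number from compound 3 to compound 4 (0.27 log units; within the scatter); a 1.5-fold higher number from compound 2 to compound 4 (0.17 log units; within the scatter); a 1.7-fold higher number from compound 1 to compound 4 (0.23 log units; within the scatter)). The step from the 2-hydroxynaphthalen-1-yl compound is the widest yet seen at this carbon, but it still does not separate the two compounds. No measurement here offers an explanation for these numbers.

Every group shown is an aromatic carbon ring. Going by these compounds, whether an amine, a carboxylic acid or a plain alkyl chain at this carbon would move the number beyond the scatter remains open.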